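Phenoxy replaces (3-nitrophenyl)amino at the assay limit

A few compounds are considered here, and "the series" means these few. Any claim that something is new, unique, unknown or untested is made for them only; others in the source may bear on it.

Compound 1, `CCOC(=O)c1[nH]c2cc(Cl)ccc2c1/C=N/NC(=O)CC1CCCC1`: in an assay for inhibition of Polyunsaturated fatty acid lipoxygenase ALOX15 (Homo sapiens), with a stated time of 8 min (on this read-out higher numbers stand for weaker inhibition and lower numbers for stronger inhibition), compound 1 gives > 10000 nM, which is a limit of the assay.
Compound 2, `CCOC(=O)c1[nH]c2cc(Cl)ccc2c1/C=N/NC(=O)CNc1cccc([N+](=O)[O-])c1`: in this assay compound 2 gives > 10000 nM, which is a limit of the assay.

Compound 2 stands at the limit of the assay, on (the limit of > 10000 nM in this assay, at which 2 of the 2 values shown sit). The step that the two limits leave unreadable from compound 1 to compound 2 is unreadable; both of its ends are limits. Compound 3, `CCOC(=O)c1[nH]c2cc(Cl)ccc2c1/C=N/NC(=O)COc1ccccc1`, differs from compound 2 by phenoxy in place of (3-nitrophenyl)amino on a saturated chain carbon bound to a carbonyl carbon. For the measured compounds named here, no measured step in this assay can be read, so none gives a direction; the only evidence is the limit of > 10000 nM in this assay, at which 2 of the 2 values shown sit. Compound 3 is therefore expected to stay at or near the limit, estimated at 15000 nM with a range from 4000 nM to 60000 nM. The step this estimate implies, a step that the limit leaves unreadable from compound 2 to compound 3, is expected to be none beyond the scatter.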

Compound 3, half-maximal inhibitory concentration: > 10000 nM
Compound 3: a limit, no number; the forecaster's own chance of this, stated with the estimate: 85%; the middle value is on the limit's open side.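

For the compounds shown here, compound 3, like compound 1 and compound 2, gives only a limit in this assay, so no step among the three can be read: the limit of > 10000 nM in this assay, at which 3 of the 3 values shown sit. The compounds shown leave open whether any group at this place gives a measurable inhibition value.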